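The source may hold more compounds than are shown below. What is called first, only, known or untested is meant among the compounds shown, and "the series" means these compounds.

Measured in an ADME assay on microsomes from liver (Homo sapiens) for metabolic stability; on this read-out higher numbers stand for fast clearance and lower numbers for slow clearance:
- compound 1 `COc1ccc([C@H](C)NC(=O)Cn2nnc3ccccc3c2=O)cc1`: 13 mL/min/kg
- compound 2 `Cc1ccc([C@H](C)NC(=O)Cn2nnc3ccccc3c2=O)c(C)c1`: 33 mL/min/kg
- compound 3 `COc1cc(C)ccc1[C@H](C)NC(=O)Cn1nnc2ccccc2c1=O`: 30 mL/min/kg

Compound 3, at 30 mL/min/kg, sits within the usual scatter of compound 2 at 33 mL/min/kg. Compound 1 gives 13 mL/min/kg, and the numbers of the other two both stand clearly higher, beyond the scatter. The next compound to consider is compound 4 `COc1ccc([C@H](C)NC(=O)Cn2nnc3ccccc3c2=O)c(OC)c1`. It differs from compound 3 by methoxy in place of methyl on an aromatic carbon, para to a large group and meta to a methoxy group.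

Going by the values given here, two measured steps bear on this change. The same exchange at a different aromatic carbon gave a 1.1-fold lower number from compound 2 to compound 3 (0.04 log units; within the scatter), which is no real change. The other step, a 2.5-fold higher number from compound 1 to compound 2 (0.40 log units; beyond the scatter), is modest and swaps methoxy for methyl in the opposite sense, although more than one group differs there. Read backwards, it hints at a lower number, but only weakly.

A small fall in this assay is therefore expected, a 1.5-fold lower number from compound 3 to compound 4 (0.18 log units; within the scatter), probably within the scatter. For compound 4 the estimated clearance is 20 mL/min/kg, with an expected range of 11 mL/min/kg to 36 mL/min/kg.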

Compound 4, clearance: 24 mL/min/kg
The estimate for compound 4 lay 1.2-fold (0.08 log units) below the measured number; the measured number falls inside the stated range.
By their numbers in this assay, from the lowest: compounds 1, 4, 3 and 2 (each within the scatter of the next, the first and the last beyond it).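

In this assay, putting methoxy in place of methyl at this carbon, para to a large group, leaves the clearance within the scatter (a 1.3-fold lower number from compound 3 to compound 4 (0.10 log units; within the scatter)). The same exchange at another aromatic carbon also stayed within the scatter, so across these two pairs it has shown no real effect. Methoxy in place of hydrogen on an aromatic carbon likewise stays within the scatter (a 1.8-fold higher number from compound 1 to compound 4 (0.27 log units; within the scatter)), and no accompanying measurement gives a reason for any of these results.

As far as these compounds go, it remains open whether a different group at this carbon, such as an amine, a carboxylic acid or a longer chain like ethoxy, would shift the clearance beyond the scatter. It is also unknown whether these methoxy exchanges would behave the same way on a different core.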